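A few compounds are considered here, and "the series" means these few. Any claim that something is new, unique, unknown or untested is made for them only; others in the source may bear on it.

Working notes on the series. Three analogues of a shared core carry numbers in a functional assay on the whole organism (blood, strain Wistar albino) for inhibition, with Rattus norvegicus as the target, read by colorimetric assay, with stated times of 15 min and 90 min, at a dose of 20 mg/kg by the oral route; on this read-out higher numbers stand for more inhibition at the one dose given (going by the name of the read-out) and lower numbers for less inhibition. Compound 1 `CCCCNC(=O)NS(=O)(=O)c1ccc(-n2nc(-c3ccccc3)ccc2=O)cc1` gives 67.4% in this assay. Compound 2 `Cc1ccc(-c2ccc(=O)n(-c3ccc(S(=O)(=O)NC(=O)NCc4ccccc4)cc3)n2)cc1` gives 64.9% in this assay. Compound 3 `CCCCNC(=O)NS(=O)(=O)c1ccc(-n2nc(-c3ccc(Cl)cc3)ccc2=O)cc1` gives 66% in this assay. Compound 3 stands second of the three numbers, with compound 2 nearest and compound 1 furthest, both gaps within the scatter, so no order among the three can be read. Within the data shown here, the one single-point step measured so far is a number 1.4 percentage points lower from compound 1 to compound 3 (within the scatter), within the scatter.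

Compound 4 `O=C(NCc1ccccc1)NS(=O)(=O)c1ccc(-n2nc(-c3ccc(Cl)cc3)ccc2=O)cc1` is not yet measured in this assay. It differs from compound 3 by phenyl in place of propyl on a saturated chain carbon bound to an amide-type nitrogen. Among the measured compounds shown here, no measured step bears directly on this change. Compound 1 and compound 2 differ in this same group and in a second place, and in this assay compound 1 gives 67.4% while compound 2 gives 64.9%, within the scatter of each other. The step is therefore expected to be a number 1 percentage points lower from compound 3 to compound 4 (within the scatter), nothing beyond the scatter. Compound 4 is estimated at 65% in this assay, with a range of 55% to 75%.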

Compound 4, a percentage reported as inhibition, in the whole organism at one dose (the size of the read-out at that dose, not a potency): 61.6%
Compound 4: the middle estimate sits 3.4 percentage points above what was measured; measured number inside the range.
By their numbers in this assay, from the lowest: compounds 4, 2, 3 and 1 (each within the scatter of the next).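

With the chloro group held on the aromatic carbon, phenyl in place of propyl on a saturated chain carbon bound to an amide-type nitrogen can now be read on its own, and it gives a number 4.4 percentage points lower from compound 3 to compound 4 (within the scatter) in this assay, so butyl and benzyl are not separated at this place. With benzyl held, chloro in place of methyl on an aromatic carbon gives a number 3.3 percentage points lower from compound 2 to compound 4 (within the scatter), so this change, too, separates nothing in the read-out. No other kind of measurement is at hand to explain either step.

Still open, as far as these compounds go, is whether a longer chain, a terminal amine or a carboxylic acid on the saturated chain would move the number beyond the scatter. From the compounds shown here alone, a methoxy group on the aromatic carbon that carries chloro in compound 4 also remains open.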